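Series notes: methyl to tert-butyl on the fused ring

This account rests on a few compounds, and the source may have more. Where it says the series, first, only, none or still open, it means among the compounds named here.

Within the data shown here, compound 2 `CCCCOC(=O)NS(=O)(=O)c1ccc(CCC)cc1-c1ccc(Cn2c(C)nc3ccccc32)cc1` stands lowest of the two numbers so far: in an assay on membranes from HEK293 cells for displacement of a labelled ligand from Type-2 angiotensin II receptor (Homo sapiens), read by radioligand binding (on this read-out lower numbers stand for stronger inhibition and higher numbers for weaker inhibition), compound 2 gives 9.4 nM, while compound 1 `CCCCOC(=O)NS(=O)(=O)c1ccc(CCC)cc1-c1ccc(Cn2cnc3ccccc32)cc1` gives 29 nM. Among the measured compounds shown here, the one measured step, a 3.1-fold lower number from compound 1 to compound 2 (0.49 log units; beyond the scatter), covers the same aromatic carbon. Compound 3 `CCCCOC(=O)NS(=O)(=O)c1ccc(CCC)cc1-c1ccc(Cn2c(C(C)(C)C)nc3ccccc32)cc1` carries tert-butyl in place of methyl on an aromatic carbon. For the measured compounds named here, only that single step bears on the change, and it was modest toward a lower number; no measured pair shows a larger group here, so the direction is uncertain. Compound 3 is therefore expected near 12 nM, with a range of 3 nM to 50 nM. This estimate means a 1.3-fold higher number from compound 2 to compound 3 (0.11 log units; within the scatter) is expected.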

Compound 3, inhibition constant: 5.3 nM
For compound 3 the middle estimate is 2.3-fold (0.35 log units) above the measured one, within the range that was stated.
By their numbers in this assay, from the lowest: compounds 3 and 2 (each within the scatter of the next); then compound 1.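

Going from methyl to tert-butyl on the aromatic carbon between two ring nitrogen atoms gives a 1.8-fold lower number from compound 2 to compound 3 (0.25 log units; within the scatter) and so shows no readable change, which means this carbon accepts the much larger group. Replacing hydrogen with tert-butyl gives a 5.5-fold lower number from compound 1 to compound 3 (0.74 log units; beyond the scatter) and so keeps the gain that methyl first showed. No evidence is at hand to explain this result.

Still open, going by these compounds, is how an amine, a carboxylic acid or a phenyl ring on this carbon would compare with tert-butyl.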